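A few compounds are considered here, and "the series" means these few. Any claim that something is new, unique, unknown or untested is made for them only; others in the source may bear on it.

Values measured in a physicochemical assay for lipophilicity, using the shake flask method, in phosphate buffer, measured as octanol-water partition, with a stated time of 30 min, at pH 7.4; on this read-out lower numbers stand for lower lipophilicity and higher numbers for higher lipophilicity:

- compound 1 `O=C(Nc1ccccc1)c1cnc(NCc2c(F)ccc3c2CCO3)n2cnnc12` gives 4.1
- compound 2 `Fc1ccc2c(c1CNc1ncc(Oc3ccccc3)c3nncn13)CCO2` gives 3.5
- compound 3 `O=C(Nc1cnc(NCc2c(F)ccc3c2CCO3)n2cnnc12)c1cccnc1` gives 2

These three compounds share a core and differ in one group on an aromatic carbon. Compound 3 stands lowest of the three. Changing that group has already moved the number clearly. The modest step is a number 0.60 log units lower from compound 1 to compound 2 (beyond the scatter), and the two large ones are a number 1.50 log units lower from compound 2 to compound 3 (beyond the scatter) and a number 2.10 log units lower from compound 1 to compound 3 (beyond the scatter).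

The next compound, compound 4 `O=C1CC2(CC2)CN1c1cnc(NCc2c(F)ccc3c2CCO3)n2cnnc12`, keeps the core and changes the group at the same place: a group of 8 heavy atoms (6 carbon, 1 nitrogen, 1 oxygen; one three-membered non-aromatic ring of carbon only, one five-membered non-aromatic ring with 1 hetero atom) in place of a group of 9 heavy atoms (6 carbon, 2 nitrogen, 1 oxygen; one six-membered aromatic ring with 1 hetero atom), on an aromatic carbon. The ((pyridin-3-yl)carbonyl)amino group leaves, and a group with a three-membered ring of carbon only and a five-membered non-aromatic ring enters. Within the data shown here, no measured step brings in this new group, so the three steps show only how far a swap at this place can reach. With compound 3 at the bottom of the measured values (2), a rise seems the likelier direction, though a modest one and well short of the largest step seen here.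

The expected change is a number 0.60 log units higher from compound 3 to compound 4 (beyond the scatter), and this is only an estimate. In this assay the estimated value for compound 4 is 2.6, with an expected range from 2 to 3.2.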

Compound 4, distribution coefficient: 1.9
The estimate for compound 4 lay 0.70 log units above the measured number, outside the stated range (below it).
By their numbers in this assay, from the lowest: compounds 4 and 3 (each within the scatter of the next); then compound 2; then compound 1.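

In this assay, the group with a three-membered ring of carbon only and a five-membered non-aromatic ring reads like the ((pyridin-3-yl)carbonyl)amino group, with a number 0.10 log units lower from compound 3 to compound 4 (within the scatter) as the step between them. Two groups with different rings, one with 1 hydrogen-bond donor and one with 0, therefore sit together at the low end of this series. The new group also stands clearly apart from the other two groups, with a number 1.60 log units lower from compound 2 to compound 4 (beyond the scatter) and a number 2.20 log units lower from compound 1 to compound 4 (beyond the scatter) as its steps, so a low number at this place requires neither a six-membered aromatic ring in the group nor a hydrogen-bond donor. Nothing measured here explains why the two groups read so alike.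

On these data alone, how the five-membered ring would read without the three-membered ring attached stays open, so the share of each ring in the number cannot be told. Also open, as far as these compounds go, is how a morpholine ring, a simple amine or a carboxylic acid on this aromatic carbon would read, and whether any of them would fall clearly under the level of compound 3 and compound 4 or stay with them.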